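Side-chain swap on a shared core: compound 2 to compound 3

This account rests on a few compounds, and the source may have more. Where it says the series, first, only, none or still open, it means among the compounds named here.

compound 1 `O=C(CN(c1nc(Cl)nc2[nH]cnc12)C1CC1)NCC(=O)OCc1ccccc1` 21.7%
compound 2 `C[C@@H](O)[C@H](NC(=O)CN(c1ncnc2c1ncn2C1CCCCO1)C1CC1)C(=O)OCc1ccccc1` 10.9%

In a functional assay on the whole organism (Tail, strain ICR) with Mus musculus as the target, in the tail flick test, with a stated time of 120 min, at a dose of 25 umol/kg by the oral route (a higher number here means a stronger effect of the compound at the dose given, a lower number a weaker effect), compound 1 gives 21.7% and compound 2 gives 10.9%. Compound 2 stands lowest of the two numbers; its gap to compound 1 lies beyond the scatter. Compound 3 `N=C(N)NCCC[C@H](NC(=O)CN(c1ncnc2c1ncn2C1CCCCO1)C1CC1)C(=O)OCc1ccccc1` differs from compound 2 by a group of 7 heavy atoms (4 carbon, 3 nitrogen; no ring) in place of a group of 3 heavy atoms (2 carbon, 1 oxygen; no ring), on a saturated chain carbon bound to an amide-type nitrogen and a carbonyl carbon. For the measured compounds named here, no step between measured compounds is available to size this change, so only a small shift in this assay is expected, upward if any, and possibly none beyond the scatter. The estimate for compound 3 is 16%, within 5% to 35%. The expected step is a number 5.1 percentage points higher from compound 2 to compound 3 (within the scatter).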

Compound 3, a percentage reported as activity, at one dose (the size of the read-out at that dose, not a potency): 38.2%
For compound 3 the middle estimate is 22.2 percentage points below the measured one; the measured number lies above the stated range.
By their numbers in this assay, from the lowest: compound 2; then compound 1; then compound 3.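

At the saturated chain carbon bound to an amide-type nitrogen and a carbonyl carbon, the side chain matters in this assay: replacing 1-hydroxyethyl with the group of 7 heavy atoms gives a number 27.3 percentage points higher from compound 2 to compound 3 (beyond the scatter) on the shared core. For the compounds shown here, this is the first sized step, and it shows that this position tolerates a much larger open-chain group without loss of effect at the dose given. Nothing measured here bears on the reason for the step.

On these data alone, it remains open whether an amine or a carboxylic acid at this position would give a similar step. A single pair also cannot show whether the step carries over to the core of compound 1.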